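The source may hold more compounds than are shown below. What is called first, only, known or untested is meant among the compounds shown, and "the series" means these compounds.

Measured compounds:
Compound 1, `O=c1[nH]c(=O)n([C@H]2C[C@H](O)[C@@H](COP(=O)(O)O)O2)cc1Br`: 34.6 ug/mL
Compound 2, `O=c1[nH]c(=O)n([C@H]2C[C@@H]3O[PH](O)(O)OC[C@H]3O2)cc1F`: 0.06 ug/mL

Both were tested in a functional assay on L1210 cells (Mus musculus) for antiproliferative activity; a higher number here means a weaker inhibitor, a lower number a stronger inhibitor. Compound 2 gives the lower of the two numbers, 0.06 ug/mL, and compound 1 gives 34.6 ug/mL, a gap well beyond the usual scatter of this assay; the two compounds differ in more than one place, so nothing is said here about which change carries that gap.

Compound 3, `O=c1[nH]c(=O)n([C@H]2C[C@@H]3O[PH](O)(O)OC[C@H]3O2)cc1Cl`, has not been measured. It differs from compound 2 in one place only: chloro in place of fluoro on an aromatic carbon. Going by the values given here, no measured pair shows this exchange, so there is no step to lean on, and the expectation rests on judgement alone. A large step toward a weaker inhibitor is expected, a 50-fold higher number from compound 2 to compound 3 (1.70 log units; beyond the scatter), well beyond the scatter, though the direction cannot be checked against any measured pair here.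

For compound 3 the expected value in this assay is therefore 3 ug/mL, with a range from 0.3 ug/mL to 30 ug/mL.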

Compound 3, concentration for 50% inhibition: 337 ug/mL
Compound 3: middle estimate off by 110-fold (2.05 log units), on the low side; measured number above the stated range.
By their numbers in this assay, from the lowest: compound 2; then compound 1; then compound 3.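

In this assay, the exchange of fluoro for chloro gives a 5600-fold higher number from compound 2 to compound 3 (3.75 log units; beyond the scatter). Going by these compounds alone, this is the first comparison in the set that changes only one place, and it shows that the number is highly sensitive to the group on this aromatic carbon, which sits meta to a large group and two atoms from the ring nitrogen. The change is small on paper: one heavy atom leaves, one heavy atom enters, and no hydrogen-bond donor, hydrogen-bond acceptor or net charge is gained or lost, so such counts alone do not capture what matters at this position. Nothing measured here accounts for the size of this step.

The compounds shown leave open how a methyl group, an iodo group or an amine on this same carbon would compare with fluoro and chloro, so a single step cannot yet show a trend across groups. They also leave open whether the exchange would have a similar effect on the core of compound 1, which carries bromo on the corresponding carbon but differs from compound 2 in more than one place.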